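This account rests on a few compounds, and the source may have more. Where it says the series, first, only, none or still open, it means among the compounds named here.

Three compounds have numbers in a functional assay on CHO-K1 cells with Glucose-dependent insulinotropic receptor (Homo sapiens) as the target, read by a luciferase reporter, with a stated time of 5 h; on this read-out higher numbers stand for larger maximal responses and lower numbers for smaller maximal responses. Compound 1 `CC(C)OC(=O)N1CCC(Oc2cccc3c2CCN3c2ccc(S(C)(=O)=O)cc2)CC1` gives 70% in this assay. Compound 2 `CC(C)OC(=O)N1CCC(Oc2ncnc3c2CCN3c2ccc(S(C)(=O)=O)cc2)CC1` gives 154% in this assay. Compound 3 `CS(=O)(=O)c1ccc(N2CCc3c(OC4CCN(C(=O)OCCF)CC4)ncnc32)c(F)c1` gives 86% in this assay. Compound 2 stands highest of the three, with compound 3 nearest and compound 1 furthest, both gaps being beyond the usual scatter, so compound 2 is the largest responder of the measured set.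

Compound 4 `Cc1cc(S(C)(=O)=O)ccc1N1CCc2c(OC3CCN(C(=O)OC(C)C)CC3)ncnc21` differs from compound 2 in one place: methyl in place of hydrogen on an aromatic carbon. Among the compounds with values here, no measured pair shows a step of this kind, so the size and direction of its effect are not known from the data. The core of compound 2 and its carbamate are kept in compound 4, and a single carbon is added on the aromatic ring carrying the methylsulfonyl group. A modest step in this assay, within or somewhat beyond the scatter, downward, is the expectation rather than a large change.

The step of a number 19 percentage points lower from compound 2 to compound 4 (beyond the scatter) is the estimated outcome of this change. Compound 4 is expected to give about 135% in this assay, with a likely range from 90% to 175%.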

Compound 4, largest response reached (reported as percent of maximum), in percent of the reference or control that the assay uses: 80%
Estimate against measurement, compound 4: 55 percentage points above; the measured number lies below the stated range.
By their numbers in this assay, from the lowest: compounds 1, 4 and 3 (each within the scatter of the next, the first and the last beyond it); then compound 2.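

In this assay, the change from 4-(methylsulfonyl)phenyl to 2-methyl-4-(methylsulfonyl)phenyl gives a number 74 percentage points lower from compound 2 to compound 4 (beyond the scatter). Within the data shown here, this pair is the first reading at this position, and it shows that the maximal response can depend strongly on one aromatic carbon ortho to a large group and meta to the methylsulfonyl group: a single added methyl there is enough to produce a large step. Nothing available explains why the response falls at this position.

As far as these compounds go, whether the loss belongs to methyl alone or extends to other groups at this carbon, such as chlorine, methoxy or nitrile, remains open. Among these compounds, also open is whether methyl at this position would give a step of similar size with a carbamate other than the one shared by compound 2 and compound 4.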